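Swapping a difluorophenyl for a methylphenyl on the shared core

The source may report more compounds than this note shows. Statements on the series, on what has been measured and on what is new or still open speak of the compounds shown alone.

Measured compounds:
- compound 1, `Fc1ccccc1Nc1nc2nonc2nc1Nc1ccccc1`: 2200 nM
- compound 2, `Fc1ccc(Nc2nc3nonc3nc2Nc2ccccc2F)c(F)c1`: 300 nM

Both compounds were tested in an assay on mitochondria from L6 cells (Rattus norvegicus) for activation, with a stated time of 90 min; on this read-out lower numbers stand for an effect already at smaller amounts and higher numbers for an effect only at larger amounts of compound. Compound 1 carries a plain phenyl on a nitrogen on an aromatic ring and gives 2200 nM. For the measured compounds named here, compound 2 has a 2,4-difluorophenyl at that nitrogen instead, and gives 300 nM, the lowest of the two numbers; the only step known, a 7.3-fold lower number from compound 1 to compound 2 (0.87 log units; beyond the scatter), is the one that separates it from compound 1.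

Compound 3, `Cc1ccc(Nc2nc3nonc3nc2Nc2ccccc2F)cc1`, is not yet measured. It differs from compound 2 in one place: 4-methylphenyl in place of 2,4-difluorophenyl on a nitrogen on an aromatic ring. Going by the values given here, the single measured step that bears on this change is a 7.3-fold lower number from compound 1 to compound 2 (0.87 log units; beyond the scatter), which shows that removing the two fluorines from this ring costs a modest amount of activity. Among the compounds with values here, a methyl is neither a fluorine nor a bare hydrogen, so no measured step covers it exactly. The expectation is that compound 3 lands between its two neighbours, with a step of a 3.0-fold higher number from compound 2 to compound 3 (0.48 log units; beyond the scatter) that is expected to be modest and upward. Compound 3 is therefore estimated at 900 nM, with a range from 300 nM to 2500 nM.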

Compound 3, half-maximal effective concentration: 2100 nM
For compound 3 the middle estimate is 2.3-fold (0.37 log units) below the measured one, within the range that was stated.
By their numbers in this assay, from the lowest: compound 2; then compounds 3 and 1 (each within the scatter of the next).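

In this assay, the gain seen at this nitrogen does not carry over to the 4-methylphenyl: replacing the 2,4-difluorophenyl gives a 7.0-fold higher number from compound 2 to compound 3 (0.85 log units; beyond the scatter), so a substituted ring at this place is not enough by itself to give the lower number. Putting methyl in place of hydrogen on an aromatic carbon of the plain phenyl gives a 1.0-fold lower number from compound 1 to compound 3 (0.02 log units; within the scatter), which means that this methyl makes no readable difference here, and of these three compounds only compound 2 stands apart from the other two. No measurement offered here bears on what lies behind this difference between the 2,4-difluorophenyl and the 4-methylphenyl.

As far as these compounds go, what a 4-fluorophenyl or a 2-fluorophenyl would give at this nitrogen stays open, so it cannot be told whether both fluorines are needed for the lower number or whether one would do. Also open, from the compounds shown here alone, is how other groups on this ring, such as a chlorine, a methoxy group or an amine, would behave in this assay.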